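A few compounds are considered here, and "the series" means these few. Any claim that something is new, unique, unknown or untested is made for them only; others in the source may bear on it.

Measured compounds:
compound 1 `COC(=O)N[C@H](C(=O)N1CCC[C@H]1C(=O)Nc1ccc([C@H]2CC[C@H](c3ccc(NC(=O)[C@@H]4CCCN4C(=O)[C@@H](NC(=O)OC)C(C)C)cc3)N2c2ccc(C(F)(F)F)cc2)cc1)C(C)C` — 4.2 h
compound 2 `COC(=O)N[C@H](C(=O)N1CCC[C@H]1C(=O)Nc1ccc([C@H]2CC[C@H](c3ccc(NC(=O)[C@@H]4CCCN4C(=O)[C@@H](NC(=O)OC)C(C)(C)C)cc3)N2c2ccc(F)cc2)cc1)C(C)(C)C` — 7.5 h

In an ADME assay on the whole organism for metabolic stability, with Rattus norvegicus as the target, at a dose of 3 mg/kg by the intravenous route (on this read-out lower numbers stand for a shorter-lived compound and higher numbers for a longer-lived compound), compound 1 gives 4.2 h, the lower of the two numbers, with compound 2 at 7.5 h within the scatter of it. Compound 3 `COC(=O)N[C@H](C(=O)N1CCC[C@H]1C(=O)Nc1ccc([C@@H]2CC[C@@H](c3ccc(NC(=O)[C@@H]4CCCN4C(=O)[C@@H](NC(=O)OC)C(C)C)cc3)N2c2ccc(C(F)(F)F)cc2)cc1)C(C)C` is not yet measured. Its difference from compound 1 is the two compounds have the same atoms and bonds and differ only in configuration as drawn: 2 of 6 stereo elements differ; a stereocentre at a saturated ring carbon is drawn R in compound 1 and S in compound 3; a stereocentre at a saturated ring carbon is drawn R in compound 1 and S in compound 3, both flipped centres sitting on saturated ring carbons of the shared core. Going by the values given here, no measured pair shows the effect of such a configuration change in this assay, so a step either way is expected to stay within the scatter, with the range kept wide. Compound 3 is estimated at 3.5 h (1.5 h to 8 h), a step of a 1.2-fold lower number from compound 1 to compound 3 (0.08 log units; within the scatter).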

Compound 3, half-life: 6 h
Estimate against measurement, compound 3: 1.7-fold (0.23 log units) below, and the stated range covers the measured number.
By their numbers in this assay, from the lowest: compounds 1, 3 and 2 (each within the scatter of the next).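

Flipping both saturated ring carbons of the shared core gives, in this assay, a 1.4-fold higher number from compound 1 to compound 3 (0.15 log units; within the scatter). Going by these compounds alone, this is the first pair to isolate configuration at these two centres, and the half-life does not separate the two forms. The comparison is a clean one because of what the pair holds constant: the fact that compounds 1 and 3 differ only in the configuration as drawn.

On these data alone, whether the same flip reads alike on the substituents of compound 2, or with only one of the two centres flipped, stays open. As far as these compounds go, how a nitrile in place of the trifluoromethyl group would behave in this assay also stays open.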